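Terminal aryl variation on the bis-benzimidazole carboxamide series

This account rests on a few compounds, and the source may have more. Where it says the series, first, only, none or still open, it means among the compounds named here.

Compound 1 `NC(=O)c1ccc2[nH]c(-c3ccc4[nH]c(-c5ccccc5)nc4c3)nc2c1`: in a functional assay on RPMI 8402 cells (Homo sapiens) for cytotoxicity (a lower number here means a stronger inhibitor, a higher number a weaker inhibitor), compound 1 gives > 25000 nM, a limit of the assay.
Compound 2 `Cc1cccc(-c2nc3cc(-c4nc5cc(C(N)=O)ccc5[nH]4)ccc3[nH]2)c1`: compound 2 gives 8200 nM.
Compound 3 `Cc1ccc(-c2nc3cc(-c4nc5cc(C(N)=O)ccc5[nH]4)ccc3[nH]2)cc1`: compound 3 gives > 25000 nM, a limit of the assay.

Compound 3 therefore stands at the limit, one of the two values that do so (the limit of > 25000 nM in this assay, at which 2 of the 3 values shown sit). Compound 4 `NC(=O)c1ccc2[nH]c(-c3ccc4[nH]c(-c5ccc6ccccc6c5)nc4c3)nc2c1` differs from compound 3 by naphthalen-2-yl in place of 4-methylphenyl on an aromatic carbon. Within the data shown here, no measured step carries a naphthalen-2-yl; the nearest are an at least 3.0-fold lower number from compound 1 to compound 2 (0.48 log units; beyond the scatter), an at least 3.0-fold higher number from compound 2 to compound 3 (0.48 log units; beyond the scatter) and a step that the two limits leave unreadable from compound 1 to compound 3, which show that the position of a methyl on the phenyl already moves the number beyond the scatter. With compound 3 at a limit, any step can only be read downward or not at all. Compound 4 is estimated at 15000 nM, between 4000 nM and 25000 nM. The expected step is an at least 1.6-fold lower number from compound 3 to compound 4 (0.22 log units; that floor lies within the scatter).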

Compound 4, half-maximal inhibitory concentration: 740 nM
Compound 4: middle estimate off by 20-fold (1.31 log units), on the high side, outside the stated range (below it).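

At this aromatic carbon between two ring nitrogen atoms, a terminal group of 2 six-membered aromatic rings of carbon only gives an 11-fold lower number from compound 2 to compound 4 (1.04 log units; beyond the scatter) and so reaches a range that neither methylphenyl reached. The readings an at least 33-fold lower number from compound 3 to compound 4 (1.52 log units; beyond the scatter) and an at least 33-fold lower number from compound 1 to compound 4 (1.52 log units; beyond the scatter) are floors only, since compounds 1 and 3 each stand at a limit: the limit of > 25000 nM in this assay, at which 2 of the 4 values shown sit.

Open, on these data alone, is whether naphthalen-1-yl would read like naphthalen-2-yl, and what an amine or a carboxylic acid on the terminal aryl would do to the number.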